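Chain swap at the aromatic nitrogen: alkyl to methoxyethyl

The source may report more compounds than this note shows. Statements on the series, on what has been measured and on what is new or still open speak of the compounds shown alone.

This account follows a series built on a shared core carrying a trimethoxybenzyl group, with the substituent on the aromatic nitrogen varied. Compound 1 `CC/C=C\Cn1c(Cc2cc(OC)c(OC)c(OC)c2)nc2c(N)ncnc21` was tested in a functional assay on MCF7 cells (Homo sapiens) for antiproliferative activity (on this read-out lower numbers stand for stronger inhibition and higher numbers for weaker inhibition), where compound 1 gives 64600 nM. Compound 2 `CCC(C)Cn1c(Cc2cc(OC)c(OC)c(OC)c2)nc2c(N)ncnc21` differs only in the chain at that nitrogen, and in this assay compound 2 gives 61700 nM. The step of a 1.0-fold lower number from compound 1 to compound 2 (0.02 log units; within the scatter) shows that exchanging one four-carbon chain for another leaves the read-out unchanged, and compound 2 and compound 1 sit within the scatter of each other, so neither can be set apart on these two numbers.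

Compound 3 `COCCn1c(Cc2cc(OC)c(OC)c(OC)c2)nc2c(N)ncnc21` is the next member. Its difference from compound 2 is methoxymethyl in place of sec-butyl on a saturated chain carbon bound to an aromatic nitrogen. Within the data shown here, the only measured step that bears on this position, a 1.0-fold lower number from compound 1 to compound 2 (0.02 log units; within the scatter), was within the scatter, so a change of the chain alone gives no ground to expect movement in this assay beyond the scatter in either direction. Compound 3 is therefore expected to give 60000 nM, within 25000 nM to 150000 nM, an expected step of a 1.0-fold lower number from compound 2 to compound 3 (0.01 log units; within the scatter).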

Compound 3, half-maximal inhibitory concentration: 64600 nM
Compound 3: middle estimate off by 1.1-fold (0.03 log units), on the low side, within the range that was stated.
By their numbers in this assay, from the lowest: compounds 2, 1 and 3 (each within the scatter of the next).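

Among these compounds, exchanging the all-carbon chain for 2-methoxyethyl put oxygen into the chain at this position for the first time, and in this assay this exchange gave a 1.0-fold higher number from compound 2 to compound 3 (0.02 log units; within the scatter) and, measured against the unsaturated chain, no change at the digits printed from compound 1 to compound 3 (within the scatter) as well. The earlier pair had compared only four-carbon hydrocarbon chains, whereas these steps show that both a change in the chain's atoms and the loss of one heavy atom, on a saturated chain carbon bound to an aromatic nitrogen, leave compound 3 within the scatter of compound 1 and compound 2, so that none of the three can be set apart on this read-out. No evidence is at hand that would account for this flat result.

On these data alone, it remains open whether any other group on this nitrogen, such as an amine, a carboxylic acid, a phenyl ring or a longer chain, would shift the number beyond the scatter. As far as these compounds go, it also remains open whether this chain matters more once the trimethoxybenzyl group on the shared core is replaced by another group.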